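The compounds below may be only part of what the source reports. "The series", "measured", "known", "first", "only" and "open" are said of these compounds alone.

Among the compounds with values here, in a functional assay on 786-0 cells (Homo sapiens) for inhibition, read by sulforhodamine B assay, with a stated time of 48 h, tested at 10 uM (on this read-out higher numbers stand for more inhibition of growth at the one concentration tested and lower numbers for less inhibition of growth), compound 2 `Clc1ccc(-c2cn3nc(-c4ccccc4)nc3s2)cc1` gives 53% and stands highest of the two numbers so far. In this assay compound 1 `COc1ccc(-c2nc3sc(-c4ccccc4)cn3n2)cc1` gives 11%. The gap between these two compounds lies beyond the scatter. Compound 3 `COc1ccc(-c2nc3sc(-c4ccc(Cl)cc4)cn3n2)cc1` differs from compound 2 by methoxy in place of hydrogen on an aromatic carbon, which is methoxy in place of hydrogen on an aromatic carbon, para to a large group. A loss of inhibition is expected, though with wide uncertainty, since compound 1 also carries methoxy and reads 11% in this assay. The expected change is a number 18 percentage points lower from compound 2 to compound 3 (beyond the scatter) in size and direction. Compound 3 is estimated at 35%, within a range of 12% to 60%.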

Compound 3, percent growth inhibition at one concentration: -75.8%
Compound 3: middle estimate off by 110.8 percentage points, on the high side; measured number below the stated range.
By their numbers in this assay, from the lowest: compound 3; then compound 1; then compound 2.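

In this assay methoxy in place of hydrogen, para to a large group, brings a large loss (a number 128.8 percentage points lower from compound 2 to compound 3 (beyond the scatter)) and takes the number below zero, which neither earlier compound did. Chloro in place of hydrogen on an aromatic carbon, with methoxy kept, also lowers the number (a number 86.8 percentage points lower from compound 1 to compound 3 (beyond the scatter)), so both changes point the same way in compound 3. No measurement shown here accounts for either step. As far as these compounds go, whether an amine, a hydroxyl or a longer alkoxy chain in place of methoxy would behave alike remains open, as does what the negative number reflects.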